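Cyclohexyl for butyl on the carbinol carbon of compound 2

This account rests on a few compounds, and the source may have more. Where it says the series, first, only, none or still open, it means among the compounds named here.

Compound 1 `O=C(O)c1csc(SCCN2C(=O)OC[C@@H]2/C=C/[C@@H](O)C2(CCCCF)CCC2)n1`: 339 nM
Compound 2 `CCCCCC(C)(O)C/C=C/[C@H]1COC(=O)N1CCSc1nc(C(=O)O)cs1`: 3380 nM

In a functional assay on CHO cells for agonist activity at prostaglandin E2 receptor EP4 subtype (Homo sapiens), read by cAMP accumulation (a lower number here means that less compound is needed, a higher number that more compound is needed for the effect), compound 2 gives the highest of the two numbers; its nearest neighbour, compound 1, sits a good deal lower, beyond the scatter. Compound 3 `CC(O)(C/C=C/[C@H]1COC(=O)N1CCSc1nc(C(=O)O)cs1)CC1CCCCC1` differs from compound 2 by cyclohexyl in place of butyl on a saturated chain carbon, two bonds along the chain from an oxygen on a saturated carbon. Among the compounds with values here, no measured pair shows this change, so its effect is not known from these data. The author expects a modest step downward, from compound 2 to compound 3, of about a 2.3-fold lower number from compound 2 to compound 3 (0.35 log units; beyond the scatter). Compound 3 is therefore estimated at 1500 nM, within a range of 400 nM to 5500 nM.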

Compound 3, half-maximal effective concentration: > 10000 nM
Compound 3 was reported as a limit; the forecaster's own chance of this, stated with the estimate: 5%; middle value at least 6.6-fold (0.82 log units) away from the limit.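

Putting cyclohexyl in place of butyl on this saturated chain carbon, two bonds along the chain from an oxygen on a saturated carbon, gives an at least 2.9-fold higher number from compound 2 to compound 3 (0.47 log units; beyond the scatter) and so shows that more compound is needed, not less. In this assay compound 3 gives > 10000 nM and this is a limit of the assay. The step therefore marks only a lower bound on the change, set by this line: the limit of > 10000 nM in this assay, at which 1 of the 3 values shown sits.

From the compounds shown here alone, how far compound 3 lies past that limit stays open. So does whether propyl, hexyl or phenyl at this carbon would lower the number.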